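Moving a chlorine on the phenyl ketone: small change expected

This account rests on a few compounds, and the source may have more. Where it says the series, first, only, none or still open, it means among the compounds named here.

Going by the values given here, compound 2 `COc1ccc(-c2sc(N)c(C(=O)c3ccc(Cl)cc3)c2CC(C)(C)C)cc1` and compound 1 `CC(C)(C)Cc1c(Br)sc(N)c1C(=O)c1cccc(Cl)c1` are the only two compounds so far measured in an assay on CHO cells for displacement of a labelled ligand from adenosine receptor A3 (Homo sapiens), read by scintillation counting, tested at 10 uM; a lower number here means less inhibition, a higher number more inhibition at the concentration tested (going by the name of the read-out). In this assay compound 2 gives 2%, and compound 1 gives 1%; the two numbers lie within the usual scatter of each other, so neither can be set above the other, and both show little inhibition at the concentration tested. Among the compounds with values here, compound 1 and compound 2 differ from each other in more than one place, so no single-change step between measured compounds is available, and their values can only be read side by side.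

Compound 3 `COc1ccc(-c2sc(N)c(C(=O)c3cccc(Cl)c3)c2CC(C)(C)C)cc1` differs from compound 2 in one place: 3-chlorophenyl in place of 4-chlorophenyl on a carbonyl carbon. Given that compound 1, which carries the 3-chlorophenyl, gives 1% and compound 2, which carries the 4-chlorophenyl, gives 2%, compound 3 is expected to show no step beyond the scatter, and no change at the digits printed from compound 2 to compound 3 (within the scatter) is the step this expectation means. Compound 3 is estimated at 2%, with a range from 0% to 12%.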

Compound 3, a percentage reported as inhibition, at one concentration (the size of the read-out at that concentration, not a potency): 2%
For compound 3 middle estimate and measured number coincide at the digits printed; the measured number falls inside the stated range.
By their numbers in this assay, from the lowest: compounds 1, 2 and 3 (each within the scatter of the next).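

In this assay, going by these compounds alone, 3-chlorophenyl in place of 4-chlorophenyl on a carbonyl carbon gives no change at the digits printed from compound 2 to compound 3 (within the scatter) and so supplies the first direct reading of this change, with everything else in the molecule held the same; the side-by-side values of the earlier pair could not isolate it. The second step, 4-methoxyphenyl in place of bromo on an aromatic carbon, gives a number 1 percentage points higher from compound 1 to compound 3 (within the scatter) with the 3-chlorophenyl held the same, so neither of the two places separates the compounds beyond the scatter in this read-out, and all the values stay at little inhibition at the concentration tested. Nothing available bears on why these steps come out as they do.

Because every value lies so close together, these compounds leave open whether either place can move the inhibition at all, since a step that stays within the scatter from such a low level says little about the reach of other groups. An amine or a carboxylic acid on the phenyl ring of the ketone, or a longer chain in place of the bromo or the 4-methoxyphenyl, lies outside what is shown here.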